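Swapping methylsulfanyl for dimethylamino in compound 1

The source may hold more compounds than are shown below. What is called first, only, known or untested is meant among the compounds shown, and "the series" means these compounds.

compound 1 `CSc1ncnc2c1c(-c1ccoc1)cn2[C@@H]1O[C@H](CO)[C@@H](O)[C@H]1O`: 280 nM
compound 2 `CSc1ncnc2c1c(-c1cccs1)cn2[C@@H]1O[C@H](CO)[C@@H](O)[C@H]1O`: > 20000 nM (a limit, not a number)
compound 3 `C#Cc1cn([C@@H]2O[C@H](CO)[C@@H](O)[C@H]2O)c2ncnc(SC)c12`: 140 nM

In a functional assay on A549 cells (Homo sapiens), read by MTT assay, with a stated time of 72 h (on this read-out lower numbers stand for stronger inhibition and higher numbers for weaker inhibition), compound 1 gives 280 nM. It stands level with the ethynyl compound, since a 2.0-fold lower number from compound 1 to compound 3 (0.30 log units; within the scatter). The thiophen-2-yl compound lies far off, with an at least 71-fold higher number from compound 1 to compound 2 (1.85 log units; beyond the scatter).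

Compound 4 `CN(C)c1ncnc2c1c(-c1ccoc1)cn2[C@@H]1O[C@H](CO)[C@@H](O)[C@H]1O` keeps the furan-3-yl group of compound 1 and changes another place on the shared core, with dimethylamino in place of methylsulfanyl on an aromatic carbon.

Among the compounds with values here, no measured step touches this place, because all three swap only the other group. They therefore give no direct size for this change. They do show that one swap on this core can leave this assay unchanged or shift it greatly, and neither step away from compound 1 gave a clearly lower number. A moderate move towards weaker inhibition is therefore expected, with wide uncertainty. The expected step is a 3.6-fold higher number from compound 1 to compound 4 (0.55 log units; beyond the scatter).

For compound 4 the estimated value is 1000 nM, with an expected range from 150 nM to 10000 nM.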

Compound 4, half-maximal inhibitory concentration: > 20000 nM
Compound 4 was reported as a limit; the forecaster's own chance of this, stated with the estimate: 20%; middle value at least 20-fold (1.30 log units) from the limit.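

Changing only this place, with dimethylamino in place of methylsulfanyl, gives an at least 71-fold higher number from compound 1 to compound 4 (1.85 log units; beyond the scatter) in this assay. Until now, only the place holding the furan-3-yl group had shown such a large shift, so this result shows that a single swap at the methylsulfanyl place can also cost nearly all the measurable activity, even though the group entering is similar in size by heavy-atom count. Compound 4 is reported as a limit, not a number, so the step gives only a minimum size: the limit of > 20000 nM in this assay, at which 2 of the 4 values shown sit.

From the compounds shown here alone, whether this loss belongs to dimethylamino in particular or to any replacement of methylsulfanyl stays open, and a plain amino group, a methoxy group or a longer chain such as ethylsulfanyl at this place would help to separate the two. Going by these compounds, it is also open whether dimethylamino would have the same effect with ethynyl in place of furan-3-yl.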